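Mirror-image urea in the whole-plant assay

The compounds below may be only part of what the source reports. "The series", "measured", "known", "first", "only" and "open" are said of these compounds alone.

Measured so far:
compound 1, `CCc1cccc(NC(=O)N[C@@H](C)c2ccccc2)c1`, 100%
compound 2, `CCOC(=O)c1cccc(NC(=O)N[C@H](C)c2ccccc2)c1`, 99%

Two ureas have been measured. In an ADME assay on the whole organism with Oryza sativa as the target, tested at 0.1 uM (a higher number here means a weaker effect of the compound at the concentration tested, a lower number a stronger effect), compound 1 gives 100%, a number at the weak end of the read-out. In this assay, among the measured compounds shown here, compound 2 gives 99%, and this number sits within the usual scatter of the one found for compound 1, so the two compounds cannot be told apart on these data. For the measured compounds named here, compound 2 is thus one of two near-identical numbers, and no step between measured compounds is available that would show what any single change does in this assay.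

The next compound, compound 3, `CCOC(=O)c1cccc(NC(=O)N[C@@H](C)c2ccccc2)c1`, has not yet been measured. It differs from compound 2 as follows: the two compounds have the same atoms and bonds and differ only in configuration as drawn: 1 of 1 stereo elements differ; a stereocentre at a saturated chain carbon is drawn R in compound 2 and S in compound 3. Going by the values given here, with no measured step to lean on, the expectation rests only on the two numbers known, both close to the top of the scale and within the scatter of each other. The step from compound 2 to compound 3 is therefore expected to be none beyond the scatter, an estimated a number 1 percentage points lower from compound 2 to compound 3 (within the scatter) in this assay. For compound 3 the estimated value in this assay is 98%, with a range from 85% to 100%.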

Compound 3, a percentage reported as activity, at one concentration (the size of the read-out at that concentration, not a potency): 100%
Compound 3: middle estimate off by 2 percentage points, on the low side; low and high end bracket the measured number.
By their numbers in this assay, from the lowest: compounds 2, 1 and 3 (each within the scatter of the next).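

In this assay, among the compounds shown here, turning the stereocentre at a saturated chain carbon from R to S gives a number 1 percentage points higher from compound 2 to compound 3 (within the scatter) and so offers the first direct look at configuration, with no effect that can be separated from the scatter. For the compounds shown here, with that configuration kept, ethoxycarbonyl in place of ethyl on an aromatic carbon gives no change at the digits printed from compound 1 to compound 3 (within the scatter) and provides the first single-place comparison at this aromatic carbon, which again does not tell the two groups apart. The mirror-image pair is a clean comparison, as only one feature separates its members: the fact that compounds 2 and 3 differ only in the configuration as drawn

All three numbers sit at the weak end of the read-out, so the data cannot say whether configuration or the group on the aromatic carbon would matter in a compound with a stronger effect in this assay. On these data alone, whether a carboxylic acid, an amine or a longer chain on that aromatic carbon would shift the number beyond the scatter remains open.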